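The source may report more compounds than this note shows. Statements on the series, on what has been measured and on what is new or still open speak of the compounds shown alone.

Compound 1 `N#CC1=C(N)Oc2c(N)cc3nc4ccccc4nc3c2C12C(=O)N(Cc1cnnn1-c1cccc(C(F)(F)F)c1)c1ccccc12` gives 15800 nM in a functional assay on HepG2 cells (Homo sapiens) for antiproliferative activity, read by MTT assay, with a stated time of 48 h; a lower number here means a stronger inhibitor, a higher number a weaker inhibitor. Compound 2 `COc1ccccc1-n1nncc1CN1C(=O)C2(C(C#N)=C(N)Oc3c(N)cc4nc5ccccc5nc4c32)c2ccccc21` reaches only the limit of > 50000 nM in this assay. Compound 3 `CCOc1ccc(-n2nncc2CN2C(=O)C3(C(C#N)=C(N)Oc4c(N)cc5nc6ccccc6nc5c43)c3ccccc32)cc1` likewise gives only the limit of > 50000 nM in this assay, so its place among the three rests on (the limit of > 50000 nM in this assay, at which 2 of the 3 values shown sit). Compound 4 `N#CC1=C(N)Oc2c(N)cc3nc4ccccc4nc3c2C12C(=O)N(Cc1cnnn1-c1ccc([N+](=O)[O-])cc1)c1ccccc12` differs from compound 3 by nitro in place of ethoxy on an aromatic carbon. Among the measured compounds shown here, the only readable steps are an at least 3.1-fold higher number from compound 1 to compound 3 (0.50 log units; beyond the scatter) and an at least 3.1-fold higher number from compound 1 to compound 2 (0.50 log units; beyond the scatter), while a step that the two limits leave unreadable from compound 2 to compound 3. For the measured compounds named here, both readable steps point toward weaker inhibition once the 3-(trifluoromethyl)phenyl is exchanged; no measured step touches a nitro group. For compound 4 an estimated step of an at least 1.4-fold lower number from compound 3 to compound 4 (0.15 log units; that floor lies within the scatter) is expected in this assay, carrying much uncertainty. Compound 4 is therefore estimated at 35000 nM, within 8000 nM to 150000 nM.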

Compound 4, half-maximal inhibitory concentration: > 50000 nM
Compound 4: a limit, no number; the forecaster's own chance of this, stated with the estimate: 55%; at least 1.4-fold (0.15 log units) between middle value and limit.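

In this assay compound 4 gives > 50000 nM, a limit and not a number. Nitro, para to a large group, therefore leaves the series at the limit as ethoxy does, and the steps among compound 2, compound 3 and compound 4 cannot be read. The 4-nitrophenyl gives an at least 3.1-fold higher number from compound 1 to compound 4 (0.50 log units; beyond the scatter), and only compound 1 stays off the shared limit: the limit of > 50000 nM in this assay, at which 3 of the 4 values shown sit.

As far as these compounds go, how compound 2, compound 3 and compound 4 rank among themselves stays open. So does what an amine or a carboxylic acid in place of nitro would give.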